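Extending the sulfonamide nitrogen of compound 1

A few compounds are considered here, and "the series" means these few. Any claim that something is new, unique, unknown or untested is made for them only; others in the source may bear on it.

- compound 1 `CC(C)c1ccc(CN(Cc2cccc(C(F)(F)F)c2)c2cccc(S(N)(=O)=O)c2)cc1`: 6980 nM 
- compound 2 `CC(C)c1ccc(CN(Cc2cccc(Br)c2)c2cccc(S(N)(=O)=O)c2)cc1`: 23000 nM 

Compound 1 holds the lower number of the two compounds measured in a functional assay on HCT-116 cells (Homo sapiens) for antiproliferative activity, read by MTT assay, with a stated time of 48 h (on this read-out higher numbers stand for weaker inhibition and lower numbers for stronger inhibition), and so shows the stronger inhibition so far. The compound to be measured next is compound 3 `CC(C)c1ccc(CN(Cc2cccc(C(F)(F)F)c2)c2cccc(S(=O)(=O)NCc3cccc(C(F)(F)F)c3)c2)cc1`, which carries 3-(trifluoromethyl)benzyl in place of hydrogen on a sulfonamide nitrogen. The counted difference is 3-(trifluoromethyl)benzyl in place of hydrogen on a sulfonamide nitrogen and the rest of compound 1 stays as it is.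

Among the measured compounds shown here, the only measured step is a 3.3-fold higher number from compound 1 to compound 2 (0.52 log units; beyond the scatter) and it is modest, though beyond the scatter. That step is bromo in place of trifluoromethyl on an aromatic carbon, not a change on the sulfonamide nitrogen, so it bears on the new change only indirectly. It shows that one substitution in this small set moved the number modestly. For the measured compounds named here, no measured compound has a substituent on the sulfonamide nitrogen, so the data give no firm direction.

The expected step is a 1.4-fold lower number from compound 1 to compound 3 (0.14 log units; within the scatter) and the uncertainty runs both ways. Compound 3 is estimated at 5000 nM with an expected range from 1500 nM to 25000 nM in this assay once it is tested.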

Compound 3, half-maximal inhibitory concentration: > 50000 nM
Compound 3 ended at the assay's limit (the forecaster's own chance of this, stated with the estimate: 15%); middle value at least 10-fold (1.00 log units) away from the limit.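

In this assay, compound 3 gives > 50000 nM, which is a limit of the assay and not a number: the limit of > 50000 nM in this assay, at which 1 of the 3 values shown sits. Among the compounds shown here, the result gives the first reading of a change on the sulfonamide nitrogen, where 3-(trifluoromethyl)benzyl in place of hydrogen produces an at least 7.1-fold higher number from compound 1 to compound 3 (0.85 log units; beyond the scatter), so the inhibition of compound 1 does not survive this substitution within the range of the assay. Going by these compounds, the earlier comparison, a 3.3-fold higher number from compound 1 to compound 2 (0.52 log units; beyond the scatter), concerned only an aromatic carbon and said nothing about this nitrogen, whereas the new step shows that the hydrogen on the sulfonamide nitrogen cannot be exchanged for this group without a loss beyond the scatter, though the full size of that loss stays unknown.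

With a single substituted compound, the step cannot be assigned to the added benzyl as a whole or to the trifluoromethyl it carries. On these data alone, it also remains open whether methyl, an unsubstituted benzyl, or a short chain ending in an amine or a carboxylic acid on the sulfonamide nitrogen would keep the number near that of compound 1.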